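Swapping nitro for cyano on a weakly active scaffold

The source may report more compounds than this note shows. Statements on the series, on what has been measured and on what is new or still open speak of the compounds shown alone.

Compound 1 `O=c1cc(N2CCNCC2)n(Cc2ccccc2)c2ccnn12` and compound 2 `O=c1cc(N2CCNCC2)n(Cc2ccccc2[N+](=O)[O-])c2ccnn12` share one core and were both tested in an ADME assay on isolated protein for inhibition of Dipeptidyl peptidase 9 (Homo sapiens), read by fluorescence, with a stated time of 10 min; on this read-out lower numbers stand for stronger inhibition and higher numbers for weaker inhibition. In this assay compound 1 gives only a limit, > 100000 nM. Compound 2 likewise gives only a limit, > 100000 nM. The step from compound 1 to compound 2, a step that the two limits leave unreadable from compound 1 to compound 2, cannot be sized because the limit of > 100000 nM in this assay, at which 2 of the 2 values shown sit, hides whatever difference exists between them. Compound 2 therefore stands at the weak end of what this assay can report, with no number of its own.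

Compound 3 `N#Cc1ccccc1Cn1c(N2CCNCC2)cc(=O)n2nccc12` is the next compound and has not yet been measured. It differs from compound 2 by cyano in place of nitro on an aromatic carbon. Among the compounds with values here, only one measured step exists, and it is unreadable, so no measured change gives guidance on the size or direction of the step from compound 2 to compound 3. Given that compound 2 sits at the limit, compound 3 is expected to remain near that limit, which is an estimated step that the limit leaves unreadable from compound 2 to compound 3. The estimate for compound 3 in this assay is 150000 nM, expected to fall between 40000 nM and 600000 nM.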

Compound 3, half-maximal inhibitory concentration: > 100000 nM
Compound 3 was reported as a limit; the forecaster's own chance of this, stated with the estimate: 80%; the middle value is on the limit's open side.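

In this assay compound 3 gives only a limit, > 100000 nM. Within the data shown here, no step among compound 1, compound 2 and compound 3 can be read, because all three sit at the same limit: the limit of > 100000 nM in this assay, at which 3 of the 3 values shown sit. The compounds shown leave open how strongly each one inhibits the enzyme, and whether hydrogen, nitro or cyano on that aromatic carbon makes any difference.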